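A few compounds are considered here, and "the series" means these few. Any claim that something is new, unique, unknown or untested is made for them only; others in the source may bear on it.

Values measured in a physicochemical assay for solubility; a lower number here means a less soluble compound, a higher number a more soluble compound:

- compound 1 `CNC(=O)c1cc(C(=O)NC2CC2)cn(Cc2ccc(C)cc2)c1=O`: 24 ug/mL
- compound 2 `CNC(=O)c1cc(C(=O)NC2CCC2)cn(Cc2ccccn2)c1=O`: >= 103 ug/mL (a limit of the assay, not a number)
- compound 3 `CNC(=O)c1cc(C(N)=O)cn(Cc2ccccc2)c1=O`: 71 ug/mL

Compound 2 sits at the limit of >= 103 ug/mL in this assay, at which 1 of the 3 values shown sits. Its true value is therefore not known, and any step that starts from it is only loosely anchored.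

The next compound to be measured is compound 4 `CNC(=O)c1cc(C(=O)NC2CCC2)cn(Cc2cccc(NC)c2)c1=O`. It carries 3-(methylamino)phenyl in place of pyridin-2-yl on a saturated chain carbon bound to an aromatic nitrogen, and the count of that change reads (3-(methylamino)phenyl in place of pyridin-2-yl on a saturated chain carbon bound to an aromatic nitrogen).

Among the compounds with values here, no two measured compounds differ in one place only, so no measured step speaks directly to this change. The nearest guide is compound 1 at 24 ug/mL, and compound 3 at 71 ug/mL is the other. Both have a six-membered aromatic ring of carbon only at this place, although they also differ from compound 2 elsewhere.

On that basis, a moderate downward move is expected in this assay, estimated as an at least 2.5-fold lower number from compound 2 to compound 4 (0.41 log units; beyond the scatter). For compound 4 the expected value is 40 ug/mL, with an estimated range of 14 ug/mL to 100 ug/mL.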

Compound 4, solubility: >= 155 ug/mL
Compound 4 was reported as a limit; the forecaster's own chance of this, stated with the estimate: 10%; at least 3.8-fold (0.58 log units) between middle value and limit.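

In this assay, compound 2 and compound 4 are both reported only as limits of the assay, and the step between them cannot be read. The compounds shown leave open the size and direction of the change from pyridin-2-yl to 3-(methylamino)phenyl.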